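The source may hold more compounds than are shown below. What is called first, only, known or untested is meant among the compounds shown, and "the series" means these compounds.

Compound 2 `CC1(C)c2[nH]nc(NC(=O)c3ccccc3)c2CN1Cc1cccc(F)c1F` and compound 1 `CC1(C)c2[nH]nc(NC(=O)c3ccccc3)c2CN1Cc1cc(F)cc(F)c1` share one core and differ only at a saturated chain carbon bound to an amine nitrogen in a ring, where (3,5-difluorophenyl in place of 2,3-difluorophenyl on a saturated chain carbon bound to an amine nitrogen in a ring). In an assay on Sf21 cells for inhibition of high affinity nerve growth factor receptor (Homo sapiens), read by HTRF, with a stated time of 30 min, in the presence of a further agent that is not named here (a higher number here means a weaker inhibitor, a lower number a stronger inhibitor), compound 2 gives 200 nM and compound 1 gives 190 nM, so a 1.1-fold lower number from compound 2 to compound 1 (0.02 log units; within the scatter). Compound 3 `CN(C)c1cccc(C(=O)Nc2n[nH]c3c2CN(Cc2cccc(F)c2F)C3(C)C)c1` carries a different core, set apart from compound 2 by dimethylamino in place of hydrogen on an aromatic carbon; in this assay compound 3 gives 420 nM, and a 2.1-fold higher number from compound 2 to compound 3 (0.32 log units; beyond the scatter). Compound 4 `CN(C)c1cccc(C(=O)Nc2n[nH]c3c2CN(Cc2cc(F)cc(F)c2)C3(C)C)c1` has not yet been measured. It differs from compound 3 by 3,5-difluorophenyl in place of 2,3-difluorophenyl on a saturated chain carbon bound to an amine nitrogen in a ring, the same change that turned compound 2 into compound 1. Because a 1.1-fold lower number from compound 2 to compound 1 (0.02 log units; within the scatter) and that step stayed within the scatter, the step from compound 3 to compound 4 in this assay is expected to be about as small, a 1.1-fold lower number from compound 3 to compound 4 (0.02 log units; within the scatter). Compound 4 is therefore estimated at 400 nM, likely between 200 nM and 800 nM.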

Compound 4, half-maximal inhibitory concentration: 270 nM
The estimate for compound 4 lay 1.5-fold (0.17 log units) above the measured number, within the range that was stated.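

In this assay, the swap from 2,3-difluorobenzyl to 3,5-difluorobenzyl gives a 1.6-fold lower number from compound 3 to compound 4 (0.19 log units; within the scatter), and it matches the same swap on the other core: the same change on two cores in this assay, a 1.1-fold lower number (0.02 log units; within the scatter) from compound 2 to compound 1 and a 1.6-fold lower number (0.19 log units; within the scatter) from compound 3 to compound 4, 1.5-fold (0.17 log units) apart, within the scatter of two such steps.
Adding dimethylamino with the 3,5-difluorobenzyl group in place gives a 1.4-fold higher number from compound 1 to compound 4 (0.15 log units; within the scatter), and this too agrees with the earlier step: the same change on two cores in this assay, a 2.1-fold higher number (0.32 log units; beyond the scatter) from compound 2 to compound 3 and a 1.4-fold higher number (0.15 log units; within the scatter) from compound 1 to compound 4, 1.5-fold (0.17 log units) apart, within the scatter of two such steps.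
So both changes carried across within the scatter in these four compounds, but the steps are small, so this is a mild test and shows nothing about larger changes or other cores.

Going by these compounds, it remains open whether a carboxylic acid or a morpholine in place of dimethylamino would carry across as well. The same applies to a longer chain in place of the benzyl link.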